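Bromo to methyl on the amide side chain of compound 1

The source may report more compounds than this note shows. Statements on the series, on what has been measured and on what is new or still open speak of the compounds shown alone.

Measured compounds:
compound 1 `COc1ccc(CN(C(=O)C(C)Br)c2cc(OC)c(OC)c(OC)c2)cc1O`: 160 nM
compound 2 `C/C=C/C(=O)N(Cc1ccc(OC)c(Br)c1)c1cc(OC)c(OC)c(OC)c1`: 10500 nM
compound 3 `C/C=C/C(=O)N(Cc1ccc(OC)c(C)c1)c1cc(OC)c(OC)c(OC)c1`: 32900 nM

Of the compounds shown here, three sharing one core have been measured in a functional assay on KYSE-450 cells (Homo sapiens) for inhibition, read by MTT assay, with a stated time of 48 h; a lower number here means a stronger inhibitor, a higher number a weaker inhibitor. Compound 1 gives 160 nM in this assay, the lowest of the three numbers, with compound 2 far higher and compound 3 higher still. Among the measured compounds shown here, the only single-point step among them is a 3.1-fold higher number from compound 2 to compound 3 (0.50 log units; beyond the scatter), a swap of a halogen for a methyl, though on an aromatic carbon rather than on the chain.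

Compound 4 `COc1ccc(CN(C(=O)C(C)C)c2cc(OC)c(OC)c(OC)c2)cc1O` is the unmeasured analogue of compound 1. The change is methyl in place of bromo on a saturated chain carbon bound to a carbonyl carbon and a saturated chain carbon. For the measured compounds named here, no measured pair reports this exchange at this place; the step from compound 2 to compound 3 is the closest relative and points toward a weaker compound, but its location differs. Compound 4 is therefore expected to give a higher number than compound 1, estimated as a step of a 9.4-fold higher number from compound 1 to compound 4 (0.97 log units; beyond the scatter). Compound 4 is expected to read about 1500 nM, within a range from 300 nM to 8000 nM.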

Compound 4, half-maximal inhibitory concentration: 390 nM
For compound 4 the middle estimate is 3.8-fold (0.59 log units) above the measured one; low and high end bracket the measured number.
By their numbers in this assay, from the lowest: compound 1; then compound 4; then compound 2; then compound 3.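

In this assay, replacing bromo with methyl on this saturated chain carbon gives a 2.4-fold higher number from compound 1 to compound 4 (0.39 log units; beyond the scatter), so the bromo group carries a real but modest part of the activity of compound 1, and compound 4 still gives 390 nM without it. The change points the same way here as on an aromatic carbon, where the step is a 3.1-fold higher number from compound 2 to compound 3 (0.50 log units; beyond the scatter), so both available pairs favour bromo over methyl. Nothing among the data presented accounts for the difference between bromo and methyl at this place.

From the compounds shown here alone, it remains open how chloro, a hydroxyl group, an amine or a longer chain would read at this carbon. The two pairs also leave open whether the same exchange would point the same way on other cores or in other cell lines.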